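The compounds below may be only part of what the source reports. "The series", "measured", "known", "first", "only" and "open" are said of these compounds alone.

Compound 1 `COC(=O)CSc1cc(-n2c(=S)n3n(c2=S)CCCC3)c(F)cc1Cl` and compound 3 `COC(=O)CSc1cc(/N=c2\sc(=S)n3n2CCCC3)c(F)cc1Cl` carry the same ((methoxycarbonyl)methyl)sulfanyl group on cores built from the same atoms joined differently; the difference between the two cores is not broken down here. In a functional assay on the whole organism for inhibition, with Echinochloa esculenta as the target (a higher number here means a weaker inhibitor, a lower number a stronger inhibitor), compound 1 gives 195 nM, and compound 3 gives 269 nM, two values that lie within the scatter of each other. Compound 2 `C#CCOc1cc(-n2c(=S)n3n(c2=S)CCCC3)c(F)cc1Cl` differs from compound 1 in one place propargyloxy in place of ((methoxycarbonyl)methyl)sulfanyl on an aromatic carbon and in this assay compound 2 gives 1.7 nM, a step of a 110-fold lower number from compound 1 to compound 2 (2.06 log units; beyond the scatter). Compound 4 `C#CCOc1cc(/N=c2\sc(=S)n3n2CCCC3)c(F)cc1Cl` stands to compound 3 as compound 2 stands to compound 1, the same change at the same place (propargyloxy in place of ((methoxycarbonyl)methyl)sulfanyl on an aromatic carbon). In this assay the step from compound 3 to compound 4 is expected to be of similar size, a 90-fold lower number from compound 3 to compound 4 (1.95 log units; beyond the scatter), because the earlier step of a 110-fold lower number from compound 1 to compound 2 (2.06 log units; beyond the scatter) was made by this very change. Compound 4 is accordingly estimated at 3 nM, with a likely range from 0.8 nM to 15 nM.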

Compound 4, half-maximal inhibitory concentration: 5.89 nM
Compound 4: the middle estimate sits 2.0-fold (0.29 log units) below what was measured, and the stated range covers the measured number.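

In this assay, putting propargyloxy in place of ((methoxycarbonyl)methyl)sulfanyl on the core of compound 3 gives a 46-fold lower number from compound 3 to compound 4 (1.66 log units; beyond the scatter). The change therefore carries over from one core to the other with a similar effect: the same change on two cores in this assay, a 110-fold lower number (2.06 log units; beyond the scatter) from compound 1 to compound 2 and a 46-fold lower number (1.66 log units; beyond the scatter) from compound 3 to compound 4, 2.5-fold (0.40 log units) apart, within the scatter of two such steps. This rests on just two cores and one pair of groups, so it does not show that the change would carry over to any other core, nor does it explain why the number falls.

The compounds shown leave open how a methoxy group, a longer alkynyloxy chain or a free carboxylic acid would behave at this place. They also leave open whether the step would persist with the chloro or fluoro group replaced by hydrogen.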